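Chloro for methyl on the aryl of compound 3

The source may report more compounds than this note shows. Statements on the series, on what has been measured and on what is new or still open speak of the compounds shown alone.

Compound 3 `Cc1cccc(-n2cc(-c3ccc(NS(=O)(=O)c4c[nH]c(=O)[nH]c4=O)cc3)nn2)c1` gives 17500 nM in a functional assay on SGC-7901 cells (Homo sapiens) for antiproliferative activity, read by MTT assay, with a stated time of 24 h (a higher number here means a weaker inhibitor, a lower number a stronger inhibitor), the highest number of the three measured compounds. Compound 1 `Cc1ccccc1-n1cc(-c2ccccc2NS(=O)(=O)c2c[nH]c(=O)[nH]c2=O)nn1` gives 9570 nM in this assay, and compound 2 `Cc1cccc(-n2cc(-c3cccc(NS(=O)(=O)c4c[nH]c(=O)[nH]c4=O)c3)nn2)c1` gives 9100 nM in this assay; both gaps to compound 3 lie within the scatter, so the three cannot be ordered. Compound 4 `O=c1[nH]cc(S(=O)(=O)Nc2ccc(-c3cn(-c4cccc(Cl)c4)nn3)cc2)c(=O)[nH]1` differs from compound 3 by chloro in place of methyl on an aromatic carbon. Going by the values given here, no step between measured compounds is known, so the change has nothing to be weighed against. With what enters matching what leaves in all that is counted, the expected step is a 1.2-fold lower number from compound 3 to compound 4 (0.07 log units; within the scatter), none beyond the scatter. Compound 4 is therefore estimated at 15000 nM, with a range from 6000 nM to 40000 nM.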

Compound 4, half-maximal inhibitory concentration: 2460 nM
Estimate against measurement, compound 4: 6.1-fold (0.79 log units) above; the whole stated range lies above it.
By their numbers in this assay, from the lowest: compound 4; then compounds 2, 1 and 3 (each within the scatter of the next).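

In this assay, going by these compounds alone, the change from 3-methylphenyl to 3-chlorophenyl gives a 7.1-fold lower number from compound 3 to compound 4 (0.85 log units; beyond the scatter) and is the only step so far. This place on the aryl, meta to a large group, therefore responds to the group it carries, even though one heavy atom replaces one heavy atom and the hydrogen-bond donor and acceptor counts stay the same. Nothing measured here accounts for the step. On these data alone, whether bromo, methoxy or an amine at this place would follow chloro remains open. So does whether chloro in place of methyl on compound 2 would give a step of similar size.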